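Ester in place of the free acid on the shared core

This account rests on a few compounds, and the source may have more. Where it says the series, first, only, none or still open, it means among the compounds named here.

Measured so far:
compound 1, `COC[C@H]1C(=O)C[C@H]2[C@@H]3CC[C@H](C(=O)O)[C@]12CC3(C)C` — 20600 nM
compound 2, `C=C1C(=O)C[C@H]2[C@@H]3CC[C@H](C(=O)O)[C@]12CC3(C)C` — 24100 nM

In a functional assay on MCF7 cells (Homo sapiens) for cytotoxicity, read by MTT assay, with a stated time of 48 h (on this read-out higher numbers stand for weaker inhibition and lower numbers for stronger inhibition), compound 1 gives 20600 nM and compound 2 gives 24100 nM; the gap between the two lies within the usual scatter, so compound 2 stands alongside compound 1 with no separation to speak of. Compound 3, `C=C1C(=O)C[C@H]2[C@@H]3CC[C@H](C(=O)OC)[C@]12CC3(C)C`, has not been measured. It differs from compound 2 by methyl in place of hydrogen on an oxygen next to a carbonyl group. Among the compounds with values here, no measured pair shows this change, so for compound 3 the expected step in this assay is none beyond the scatter, in either direction, estimated as a 1.2-fold lower number from compound 2 to compound 3 (0.08 log units; within the scatter). Compound 3 is therefore expected at about 20000 nM, with a likely range from 7000 nM to 60000 nM.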

Compound 3, half-maximal inhibitory concentration: 16700 nM
Beside the measured number, compound 3's estimate is 1.2-fold (0.08 log units) above it, within the range that was stated.
By their numbers in this assay, from the lowest: compounds 3, 1 and 2 (each within the scatter of the next).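

In this assay, within the data shown here, methyl in place of hydrogen on an oxygen next to a carbonyl group gives a 1.4-fold lower number from compound 2 to compound 3 (0.16 log units; within the scatter), the first reading of this position. Carboxy and methoxycarbonyl therefore cannot be told apart in this assay on the shared core, and the free acid hydrogen is not required for the activity seen with compound 2. No available evidence bears on this result. From the compounds shown here alone, whether a longer chain on that oxygen, such as ethyl or benzyl, or an amide in place of the ester would separate from compound 2 remains open.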